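The source may hold more compounds than are shown below. What is called first, only, known or untested is meant among the compounds shown, and "the series" means these compounds.

Compound 1 `CN(C)CCn1cnnc1-c1cc(Oc2ccc(NC(=O)N/N=C/c3cccc(Br)c3)cc2F)ccn1` is the reference here. In an ADME assay on WI-38 cells (Homo sapiens) for cytotoxicity, read by MTT assay, with a stated time of 72 h (a higher number here means a weaker inhibitor, a lower number a stronger inhibitor), compound 1 gives 4230 nM, the lowest of the two numbers in hand; compound 2 `CN(C)CCn1cnnc1-c1cc(Oc2ccc(NC(=O)N/N=C/c3cccc(Cl)c3Cl)cc2F)ccn1` gives 6130 nM, and the step of a 1.4-fold higher number from compound 1 to compound 2 (0.16 log units; within the scatter) stays within the scatter, so the two cannot be ordered. Compound 3 `Cc1cc(/C=N/NC(=O)Nc2ccc(Oc3ccnc(-c4nncn4CCN(C)C)c3)c(F)c2)cc(C)c1O` is not yet measured and differs from compound 1 in one place: 4-hydroxy-3,5-dimethylphenyl in place of 3-bromophenyl on a carbon with a double bond to nitrogen. Within the data shown here, the only measured step concerns a different swap on the same carbon, 2,3-dichlorophenyl in place of 3-bromophenyl, and it barely moved this assay; it bears on the present change only loosely, since the entering group is not a halogen-bearing ring. On that evidence no step beyond the scatter is expected in this assay. Compound 3 is estimated at 6000 nM, with a range of 2000 nM to 20000 nM. That estimate means an expected step of a 1.4-fold higher number from compound 1 to compound 3 (0.15 log units; within the scatter), within the usual scatter.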

Compound 3, half-maximal inhibitory concentration: 3610 nM
Beside the measured number, compound 3's estimate is 1.7-fold (0.22 log units) above it; low and high end bracket the measured number.
By their numbers in this assay, from the lowest: compounds 3, 1 and 2 (each within the scatter of the next).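

In this assay, the step of a 1.2-fold lower number from compound 1 to compound 3 (0.07 log units; within the scatter) and the step of a 1.7-fold lower number from compound 2 to compound 3 (0.23 log units; within the scatter) show that the reading at this carbon with a double bond to nitrogen stays within the scatter even when the ring carries no halogen. The earlier pair held only halogen-bearing rings, whereas 4-hydroxy-3,5-dimethylphenyl brings a hydroxy group and two methyl groups, with 1 hydrogen-bond donor and 1 hydrogen-bond acceptor, and the three compounds still cannot be ordered. No measurement is available that bears on the reason for this result.

As far as these compounds go, whether an amine, a carboxylic acid or a longer alkyl chain in place of the aromatic ring would give a step beyond the scatter remains open. The compounds shown also leave the contributions of the hydroxy group and the two methyl groups of compound 3 unseparated.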